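A few compounds are considered here, and "the series" means these few. Any claim that something is new, unique, unknown or untested is made for them only; others in the source may bear on it.

Measured so far in a functional assay on A549 cells (Homo sapiens) for cytotoxicity, read by MTT assay, with a stated time of 72 h; on this read-out higher numbers stand for weaker inhibition and lower numbers for stronger inhibition:
compound 1 `CCc1ccc(-c2cc(C(=O)Nc3ccc(Oc4ccnc(C(=O)NC)c4)c(F)c3)ncn2)cc1`: 3390 nM
compound 2 `CNC(=O)c1cc(Oc2ccc(NC(=O)c3cc(-c4ccccc4)ncn3)cc2F)ccn1`: 23200 nM

For the measured compounds named here, compound 2 holds the higher of the two numbers, so it is the weaker inhibitor of the pair, and compound 1 is its only neighbour. Compound 3 `CNC(=O)c1cc(Oc2ccc(NC(=O)c3cc(-c4ccc(OC)cc4)ncn3)cc2F)ccn1` is not yet measured in this assay. Its difference from compound 2 is methoxy in place of hydrogen on an aromatic carbon, or phenyl to 4-methoxyphenyl. Going by the values given here, one measured step bears on this change, at the same place on that ring: a 6.8-fold higher number from compound 1 to compound 2 (0.84 log units; beyond the scatter). Losing ethyl there raised the number, so a group entering at that place is expected to lower it, though methoxy is untested and one step is thin evidence. The expected step is a 2.6-fold lower number from compound 2 to compound 3 (0.41 log units; beyond the scatter), modest and no larger than the ethyl step. For compound 3 the estimated value is 9000 nM, with an expected range of 3000 nM to 26000 nM.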

Compound 3, half-maximal inhibitory concentration: 34500 nM
For compound 3 the middle estimate is 3.8-fold (0.58 log units) below the measured one; the whole stated range lies below it.
By their numbers in this assay, from the lowest: compound 1; then compounds 2 and 3 (each within the scatter of the next).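

In this assay, the change from phenyl to 4-methoxyphenyl gives a step within the scatter (a 1.5-fold higher number from compound 2 to compound 3 (0.17 log units; within the scatter)), so a group entering at this aromatic carbon does not by itself bring the lower number seen with ethyl. Ethyl and methoxy at the same place stand clearly apart (a 10-fold higher number from compound 1 to compound 3 (1.01 log units; beyond the scatter)), which shows that the outcome at this position depends on which group enters, and of the three groups shown only ethyl stands apart. Nothing available explains this gap between ethyl and methoxy.

As far as these compounds go, it remains open whether the lower number belongs to ethyl alone or extends to a longer chain such as propyl. From the compounds shown here alone, an amine or a chlorine atom at this place is also open, as is the effect of ethyl at other carbons of this ring.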